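Swapping the amide group at the assay limit

This account rests on a few compounds, and the source may have more. Where it says the series, first, only, none or still open, it means among the compounds named here.

Measured in a functional assay on MCF7 cells (Homo sapiens) for antiproliferative activity, read by MTT assay, with a stated time of 48 h; on this read-out higher numbers stand for weaker inhibition and lower numbers for stronger inhibition:
- compound 1 `CCn1c(C(=O)NCC#N)ccc1C(CC)(CC)c1ccc(OCCC(O)(CC)CC)c(C)c1`: > 50000 nM, a limit
- compound 2 `C#CCCOC(=O)c1ccc(C(CC)(CC)c2ccc(OCCC(O)(CC)CC)c(C)c2)n1CC`: > 50000 nM, a limit
- compound 3 `CCn1c(C(=O)Nc2ccc(OC(F)(F)F)cc2)ccc1C(CC)(CC)c1ccc(OCCC(O)(CC)CC)c(C)c1`: > 50000 nM, a limit

Compound 3 has no exact number, only the limit shown, and it is not alone: the set stands at the limit of > 50000 nM in this assay, at which 3 of the 3 values shown sit. Compound 4 `CCOC(=O)C(CC(=O)OC)NC(=O)c1ccc(C(CC)(CC)c2ccc(OCCC(O)(CC)CC)c(C)c2)n1CC` keeps the shared core and changes one group: a group of 11 heavy atoms (7 carbon, 4 oxygen; no ring) in place of a group of 11 heavy atoms (7 carbon, 1 oxygen, 3 fluorine; one six-membered aromatic ring of carbon only), on an amide-type nitrogen. The 4-(trifluoromethoxy)phenyl leaves, and the group that enters has no ring.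

The closest measured change, on the same amide-type nitrogen, is a step that the two limits leave unreadable from compound 1 to compound 3. Two further changes in this part of the molecule bear on it: a step that the two limits leave unreadable from compound 1 to compound 2 and a step that the two limits leave unreadable from compound 2 to compound 3. None of the three gives a size to carry over. Because of the limit of > 50000 nM in this assay, at which 3 of the 3 values shown sit, shared by compound 1, compound 2 and compound 3, no step beyond the scatter is expected in this assay, in either direction. The expected result is a number no higher from compound 3 to compound 4 (the limit leaves the size open). A report of only a limit is the likeliest outcome for the unmeasured compound. The estimate for compound 4 is 50000 nM, with an expected range from 25000 nM to 100000 nM.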

Compound 4, half-maximal inhibitory concentration: 390 nM
For compound 4 the middle estimate is 130-fold (2.11 log units) above the measured one, outside the stated range (below it).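

In this assay, the group on the amide-type nitrogen can clearly change the result: replacing the 4-(trifluoromethoxy)phenyl with a group that has no ring gives an at least 120-fold lower number from compound 3 to compound 4 (2.10 log units; beyond the scatter). The comparison with the small cyanomethyl group on that same nitrogen points the same way, with an at least 120-fold lower number from compound 1 to compound 4 (2.10 log units; beyond the scatter), and the change on the carbonyl carbon from the (but-3-yn-1-yl)oxy group, which also brings in the amide-type nitrogen, gives an at least 120-fold lower number from compound 2 to compound 4 (2.10 log units; beyond the scatter), so all three readable steps fall in one direction. The steps among the three earlier compounds cannot be read, and they could not show that this part of the molecule responds at all, because those compounds share one limit: the limit of > 50000 nM in this assay, at which 3 of the 4 values shown sit.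

Compound 4 is the only exact number here, so the compounds shown cannot separate the effect of losing the ring from that of the oxygen atoms brought in by the entering group. Going by these compounds, whether a carboxylic acid in place of either ester, or a plain alkyl chain of similar length on the amide-type nitrogen, would keep this level of inhibition remains open.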